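Methyl on selenium: from compound 2 to compound 4

The source may hold more compounds than are shown below. What is called first, only, known or untested is meant among the compounds shown, and "the series" means these compounds.

The three measured compounds share one core and differ only at an aromatic carbon. In a functional assay on MCF7 cells (Homo sapiens) for cytotoxicity, read by MTT assay, with a stated time of 72 h (a higher number here means a weaker inhibitor of growth, a lower number a stronger inhibitor of growth), compound 1 `COc1ccc(CNc2nc([SeH])nc3ccccc23)cc1` gives 42700 nM, and compound 2 `CSc1ccc(CNc2nc([SeH])nc3ccccc23)cc1` gives 48100 nM. Compound 2 holds the highest of the two numbers, compound 1 being nearest, and a 1.1-fold higher number from compound 1 to compound 2 (0.05 log units; within the scatter) stays inside the scatter. Compound 3 `[SeH]c1nc(NCc2ccccc2)c2ccccc2n1` gives > 100000 nM, which is a limit of this assay and not a number. That limit is the one at the limit of > 100000 nM in this assay, at which 1 of the 3 values shown sits. The steps of an at least 2.3-fold higher number from compound 1 to compound 3 (0.36 log units; beyond the scatter) and an at least 2.0-fold higher number from compound 2 to compound 3 (0.31 log units; beyond the scatter) are at least modest. Compound 4 `CSc1ccc(CNc2nc([Se]C)nc3ccccc23)cc1` differs from compound 2 by methyl in place of hydrogen on a selenium. Among the compounds with values here, none of the measured steps touches the selenium, so none bears directly on this change. No step beyond the scatter is expected in this assay, an expected 1.0-fold higher number from compound 2 to compound 4 (0.02 log units; within the scatter). Compound 4 is thus expected to give 50000 nM, between 20000 nM and 125000 nM.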

Compound 4, concentration for 50% growth inhibition: 54100 nM
Compound 4: the middle estimate sits 1.1-fold (0.03 log units) below what was measured; measured number inside the range.
By their numbers in this assay, from the lowest: compounds 1, 2 and 4 (each within the scatter of the next). At a limit, above all of these: compound 3.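

Within the data shown here, compound 4 is the only compound here changed at the selenium, and in this assay the step is a 1.1-fold higher number from compound 2 to compound 4 (0.05 log units; within the scatter). Compounds 2 and 4 cannot be told apart, so with methylsulfanyl on the aromatic carbon, the hydrogen on selenium is not needed for a number of this size. Nothing available bears on this step.

Going by these compounds, whether a longer chain on the selenium, such as benzyl, or a chain ending in a carboxylic acid would read the same remains open. So does whether methyl on selenium reads the same with methoxy on the aromatic carbon.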